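Compound 3 to compound 4: exchanging the aryl group

The compounds below may be only part of what the source reports. "The series", "measured", "known", "first", "only" and "open" are said of these compounds alone.

Among the compounds with values here, in an ADME assay on S9 fraction from liver (Rattus norvegicus) for metabolic stability, read by LC-MS, using NADPH, with a stated time of 30 min (a higher number here means that more of the compound is left, a lower number that less of the compound is left), compound 3 (`CCCCCCCCc1ccc(OCC(=O)Cn2nnnc2-c2cccc(Cl)c2)cc1`) gives 41%, the only true number so far. Compound 1 (`CCCCCCCCc1ccc(OCC(=O)Cn2nnc(SC)n2)cc1`) gives < 5%, which is a limit and not a number. Compound 2 (`CCCCCCCCc1ccc(OCC(=O)Cn2nnc(-c3ccc(C(=O)O)cc3)n2)cc1`) gives < 5%, again a limit. This leaves (the limit of < 5% in this assay, at which 2 of the 3 values shown sit).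

Compound 4 (`CCCCCCCCc1ccc(OCC(=O)Cn2nnnc2-c2cccs2)cc1`) has thiophen-2-yl in place of 3-chlorophenyl on an aromatic carbon.

Within the data shown here, the only measured step is a step that the two limits leave unreadable from compound 1 to compound 2. It has no readable size and involves neither of these groups, so it offers no size to carry over to this exchange. Among the measured compounds shown here, no measured pair shows the exchange itself. The expectation for this assay therefore rests on compound 3 at 41%, with a wide margin on either side. The expected change is a number 6 percentage points lower from compound 3 to compound 4 (within the scatter), a small downward shift that stays within the scatter. For compound 4 the estimated value is 35%, with an expected range of 12% to 58%.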

Compound 4, percent of the compound remaining: 27%
Compound 4: the middle estimate sits 8 percentage points above what was measured; measured number inside the range.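

In this assay, within the data shown here, the exchange of 3-chlorophenyl for thiophen-2-yl gives a number 14 percentage points lower from compound 3 to compound 4 (beyond the scatter) and is the first step with a readable size. Compound 4, like compound 3, gives a true number and not a limit, so both aryl groups on this aromatic carbon leave a measurable amount of compound. The steps involving compounds at the limit cannot be read: the limit of < 5% in this assay, at which 2 of the 4 values shown sit.

The single exchange changes the ring size, brings in sulfur and removes chlorine all at once, so the compounds shown do not separate these three changes. Also open, on these data alone, is how an unsubstituted phenyl, a 3-methoxyphenyl or a pyridine ring on this carbon would compare with 3-chlorophenyl and thiophen-2-yl in this assay under the same conditions.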